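Adding groups to the phenyl of compound 2

The source may report more compounds than this note shows. Statements on the series, on what has been measured and on what is new or still open speak of the compounds shown alone.

Compound 1 `CCN(CC)c1ccc(N2C(=O)CSC2c2cccc(C(=O)NCCCCc3ccccc3)c2)cc1` gives > 1000 nM as a limit of the assay
Compound 2 `O=C(NCCCCc1ccccc1)c1cccc(C2SCC(=O)N2c2ccccc2)c1` gives 15.9 nM

Going by the values given here, in a functional assay on HOS-TE85 cells (Homo sapiens) for inhibition, read by CCK-8 assay, with a stated time of 72 h (on this read-out higher numbers stand for weaker inhibition and lower numbers for stronger inhibition), compound 2 gives 15.9 nM as the only exact number so far. Compound 1 reaches only the limit of > 1000 nM in this assay, at which 1 of the 2 values shown sits, and so has no exact number. Compound 3 `COc1cc(F)ccc1N1C(=O)CSC1c1cccc(C(=O)NCCCCc2ccccc2)c1` carries a new group on the shared core: 4-fluoro-2-methoxyphenyl in place of phenyl on an amide-type nitrogen in a ring. Among the compounds with values here, one measured step bears on this, the large at least 62-fold lower number from compound 1 to compound 2 (1.79 log units; beyond the scatter) with hydrogen in place of diethylamino on an aromatic carbon. That different group cost much activity, so a smaller loss is expected here. The expected step is a 3.1-fold higher number from compound 2 to compound 3 (0.50 log units; beyond the scatter) toward weaker inhibition. In this assay compound 3 is estimated at 50 nM with a range from 10 nM to 300 nM overall.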

Compound 3, half-maximal inhibitory concentration: 71.1 nM
For compound 3 the middle estimate is 1.4-fold (0.15 log units) below the measured one; measured number inside the range.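

In this assay, replacing phenyl on the amide-type nitrogen in a ring with 4-fluoro-2-methoxyphenyl gives a 4.5-fold higher number from compound 2 to compound 3 (0.65 log units; beyond the scatter), so this position can carry added groups at a modest loss, not only the large loss seen with 4-(diethylamino)phenyl. Between the two substituted phenyls, the change gives an at least 14-fold lower number from compound 1 to compound 3 (1.14 log units; beyond the scatter). The true size of that step is unknown, as compound 1 has only a limit of the assay: the limit of > 1000 nM in this assay, at which 1 of the 3 values shown sits.

The fluoro and methoxy groups enter together, which leaves their separate shares in the loss open. From the compounds shown here alone, the outcome for a hydroxyl or a carboxylic acid on this phenyl also stays open.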